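The source may hold more compounds than are shown below. What is called first, only, known or untested is meant among the compounds shown, and "the series" means these compounds.

Measured compounds:
compound 1, `CN1CCC[C@H]1[C@H]1COc2cc(O)ccc2O1`, 6000 nM;
compound 2, `CN1CCC[C@H]1[C@H]1COc2c(O)cccc2O1`, > 100000 nM;
compound 3, `CN1CCC[C@H]1[C@H]1COc2cc(-c3ccccc3)ccc2O1`, 5800 nM.

In an assay on membranes from HEK293 cells for displacement of a labelled ligand from Neuronal acetylcholine receptor; alpha3/beta4 (Homo sapiens), with a stated time of 5 min (on this read-out lower numbers stand for stronger inhibition and higher numbers for weaker inhibition), compound 1 gives 6000 nM. Compound 3 gives 5800 nM in this assay. The step of a 1.0-fold lower number from compound 1 to compound 3 (0.01 log units; within the scatter) comes from the change (phenyl in place of hydroxy on an aromatic carbon). Compound 2 gives > 100000 nM, which is a limit of the assay and not a number. Compound 2 therefore sits at the limit of > 100000 nM in this assay, at which 1 of the 3 values shown sits. Compound 2 has the same atoms as compound 1, joined differently; the difference between the two cores is not broken down here.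

Compound 4, `CN1CCC[C@H]1[C@H]1COc2c(cccc2-c2ccccc2)O1`, is not yet measured. It differs from compound 2 by phenyl in place of hydroxy on an aromatic carbon. This is the same kind of change as from compound 1 to compound 3, but the place differs: ortho to a fused ring and meta to a fused ring here, against meta to a fused ring and para to a fused ring there. Since that change produced a 1.0-fold lower number from compound 1 to compound 3 (0.01 log units; within the scatter), compound 4 is expected to stay near compound 2, with an estimated step of an at least 1.2-fold lower number from compound 2 to compound 4 (0.09 log units; that floor lies within the scatter). Compound 4 is estimated at 80000 nM, between 20000 nM and 300000 nM, and a limit is likely again.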

Compound 4, inhibition constant: 5300 nM
For compound 4 the middle estimate is 15-fold (1.18 log units) above the measured one, outside the stated range (below it).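

In this assay, phenyl in place of hydroxy on an aromatic carbon does not carry over as a single fixed step, as the two cores give clearly different results: the same change on two cores in this assay, a 1.0-fold lower number (0.01 log units; within the scatter) from compound 1 to compound 3 and an at least 18-fold lower number (1.27 log units; beyond the scatter) from compound 2 to compound 4, at least 18-fold (1.26 log units) apart, beyond the scatter of two such steps. The value of compound 2, > 100000 nM, is a limit of the assay and not a number, so an at least 18-fold lower number from compound 2 to compound 4 (1.27 log units; beyond the scatter) gives only a floor for that step. These two pairs show that the outcome of this change cannot be assumed from one core to the other, but they do not show why the steps differ or give a rule for other cores.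

The compounds shown compare only hydroxy and phenyl at these places. From the compounds shown here alone, it remains open whether a methoxy group, an amine or a carboxylic acid there would follow the step to compound 3 or the step to compound 4.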